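The source may report more compounds than this note shows. Statements on the series, on what has been measured and on what is new or still open speak of the compounds shown alone.

Compound 1 `C/C(=N\Nc1nc(-c2ccccc2)cs1)c1sc(C)nc1C` is the reference point in a toxicity assay on MCF7 cells (Homo sapiens) for cytotoxicity, read by MTT assay; a higher number here means a weaker inhibitor of growth, a lower number a stronger inhibitor of growth. In this assay compound 1 gives only a limit, > 100 ug/mL. Compound 2 `COc1ccc(-c2csc(N/N=C(\C)c3sc(C)nc3C)n2)cc1` also gives only a limit in this assay, > 100 ug/mL. The step that the two limits leave unreadable from compound 1 to compound 2 is therefore unreadable, which rests on (the limit of > 100 ug/mL in this assay, at which 2 of the 2 values shown sit). Compound 3 `C/C(=N\Nc1nc(-c2ccccc2)cs1)c1sc(-c2ccccc2)nc1C` differs from compound 1 by phenyl in place of methyl on an aromatic carbon. Going by the values given here, no measured step bears on this change, and compound 1 itself stands only at a limit, so in this assay no step beyond the scatter is expected in either direction. Compound 3 is thus expected to give 120 ug/mL, between 40 ug/mL and 400 ug/mL, most probably reported again as a limit; the expected step is a step that the limit leaves unreadable from compound 1 to compound 3.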

Compound 3, concentration for 50% growth inhibition: > 100 ug/mL
Compound 3: only a limit was reported; the forecaster's own chance of this, stated with the estimate: 70%; the middle value does not contradict the limit.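

No step can be read from compound 1 to compound 3 in this assay, since both give only a limit: the limit of > 100 ug/mL in this assay, at which 3 of the 3 values shown sit. The compounds shown leave open whether any change to the shared core gives a readable value in this assay.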